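The source may report more compounds than this note shows. Statements on the series, on what has been measured and on what is new or still open speak of the compounds shown alone.

Compound 1 `CCCC(C)(C)/N=C(\NC#N)Nc1cccnc1` gives 1 mg/kg in a functional assay on the whole organism (blood, strain Wistar-Okamoto) with Rattus norvegicus as the target, with a stated time of 5 days; on this read-out lower numbers stand for an effect already at smaller amounts and higher numbers for an effect only at larger amounts of compound. Compound 2 `CC(C)CC(C)(C)/N=C(\NC#N)Nc1cccnc1` carries the change methyl in place of hydrogen on a saturated chain carbon bound to two saturated chain carbons and gives 2.5 mg/kg in this assay; the step of a 2.5-fold higher number from compound 1 to compound 2 (0.40 log units; beyond the scatter). Compound 3 `CC(C)(C)/N=C(\NC#N)Nc1ccncc1` rests on another core; the difference between the two cores is not broken down here. In this assay compound 3 gives 2.5 mg/kg, level with compound 2. Compound 4 `CCC(C)(C)/N=C(\NC#N)Nc1ccncc1` has not yet been measured. It differs from compound 3 by methyl in place of hydrogen on a saturated chain carbon, two bonds along the chain from a double-bonded nitrogen, the same kind of change as that from compound 1 to compound 2, though there the methyl entered on a saturated chain carbon bound to two saturated chain carbons, here on a saturated chain carbon two bonds along the chain from a double-bonded nitrogen. Compound 4 is expected to show a step of a 1.6-fold higher number from compound 3 to compound 4 (0.20 log units; within the scatter) in this assay, because the earlier step of a 2.5-fold higher number from compound 1 to compound 2 (0.40 log units; beyond the scatter) was modest. Compound 4 is therefore estimated at 4 mg/kg, between 2 mg/kg and 8 mg/kg.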

Compound 4, minimum effective dose: 2.5 mg/kg
Compound 4: middle estimate off by 1.6-fold (0.20 log units), on the high side; the measured number falls inside the stated range.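

In this assay, the added methyl gives no change at the digits printed from compound 3 to compound 4 (within the scatter), while on the other core it gave a 2.5-fold higher number from compound 1 to compound 2 (0.40 log units; beyond the scatter). The two steps cannot be told apart: the same change on two cores in this assay, a 2.5-fold higher number (0.40 log units; beyond the scatter) from compound 1 to compound 2 and no change at the digits printed (within the scatter) from compound 3 to compound 4, 2.5-fold (0.40 log units) apart, within the scatter of two such steps

Going by these compounds alone, this shows no measurable difference between the cores for this change, but with only one pair on each core, and the methyl entering on differently placed chain carbons, it does not show that the change carries over unaltered. The compounds shown leave open how a cyclohexyl group or a longer branched chain in this part of the molecule would read in this assay. They also leave open whether a hydroxyl or an amine on the chain would follow the same course on both cores.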